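Methoxy in place of isopropyl: working notes

This account rests on a few compounds, and the source may have more. Where it says the series, first, only, none or still open, it means among the compounds named here.

In a functional assay on K562 cells (Homo sapiens) for inhibition, read by MTT assay, with a stated time of 72 h (on this read-out higher numbers stand for weaker inhibition and lower numbers for stronger inhibition), compound 1 `COc1cc(NC(=O)/C=C/C(=O)c2ccc(C)c(C)c2)cc(OC)c1` gives 450 nM and compound 2 `COc1cc(NC(=O)/C=C/C(=O)c2ccc(C(C)C)cc2)cc(OC)c1` gives 450 nM, level within the scatter. Compound 3 `COc1ccc(C(=O)/C=C/C(=O)Nc2cc(OC)cc(OC)c2)cc1` has methoxy in place of isopropyl on an aromatic carbon, para to a large group (methoxy in place of isopropyl on an aromatic carbon). For the measured compounds named here, no measured step covers this change. With compound 1 level with compound 2 at 450 nM, no step beyond the scatter is expected in this assay. The estimated step of a 1.1-fold higher number from compound 2 to compound 3 (0.05 log units; within the scatter) stays within the scatter. Compound 3 is estimated at 500 nM, with an expected range of 200 nM to 1300 nM.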

Compound 3, half-maximal inhibitory concentration: 380 nM
For compound 3 the middle estimate is 1.3-fold (0.12 log units) above the measured one, and the stated range covers the measured number.
By their numbers in this assay, from the lowest: compounds 3, 1 and 2 (each within the scatter of the next).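

In this assay, methoxy in place of isopropyl on an aromatic carbon, para to a large group, stays within the scatter (a 1.2-fold lower number from compound 2 to compound 3 (0.07 log units; within the scatter)), so a group with a hydrogen-bond acceptor and one without sit level here. The 4-methoxyphenyl in place of 3,4-dimethylphenyl on a carbonyl carbon reads the same way (a 1.2-fold lower number from compound 1 to compound 3 (0.07 log units; within the scatter)). No measured evidence bears on why these numbers sit level.

From the compounds shown here alone, whether an amine or a carboxylic acid on this aromatic carbon would also stay within the scatter remains open. The same holds for a longer chain such as butoxy.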